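Replacing fluoro with 2-hydroxyethyl: working notes on compound 4

The source may report more compounds than this note shows. Statements on the series, on what has been measured and on what is new or still open speak of the compounds shown alone.

Measured in a functional assay (mast cells) for inhibition, with Rattus norvegicus as the target; a higher number here means that more compound is needed for the effect, a lower number that less compound is needed:
- compound 1 `CC1CC/C(=N\Nc2ccccc2F)c2ncc(C(=O)O)c(=O)n21` gives 1200 nM
- compound 2 `CC1CC/C(=N\Nc2ccc(F)cc2)c2ncc(C(=O)O)c(=O)n21` gives 1200 nM
- compound 3 `Cc1cccc(N/N=C2\CCC(C)n3c2ncc(C(=O)O)c3=O)c1` gives 72900 nM

Compound 1 stands level with compound 2, and the two share the lowest value of the three. The next analogue is compound 4 `CC1CC/C(=N\Nc2ccccc2CCO)c2ncc(C(=O)O)c(=O)n21`, with 2-hydroxyethyl in place of fluoro on an aromatic carbon, ortho to a large group: 2-hydroxyethyl in place of fluoro on an aromatic carbon. Within the data shown here, two measured steps bear on it. With 4-fluorophenyl in place of 2-fluorophenyl, the result is no change at the digits printed from compound 1 to compound 2 (within the scatter). With 3-methylphenyl in place of 2-fluorophenyl, the large result is a 61-fold higher number from compound 1 to compound 3 (1.78 log units; beyond the scatter). Among the measured compounds shown here, no measured compound carries 2-hydroxyethyl, so a moderate rise in this assay is expected. The expected change is a 4.2-fold higher number from compound 1 to compound 4 (0.62 log units; beyond the scatter). Compound 4 is estimated at 5000 nM, with an expected range of 800 nM to 40000 nM.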

Compound 4, half-maximal effective concentration: 330000 nM
Compound 4: middle estimate off by 66-fold (1.82 log units), on the low side, outside the stated range (above it).
By their numbers in this assay, from the lowest: compounds 1 and 2 (each within the scatter of the next); then compound 3; then compound 4.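

In this assay, 2-hydroxyethyl in place of fluoro on an aromatic carbon, ortho to a large group, gives a 280-fold higher number from compound 1 to compound 4 (2.44 log units; beyond the scatter). This place on the ring therefore does not keep the number at the level of compound 1 for every group: here the place is unchanged and the group alone differs. Nothing available accounts for the rise.

Open, from the compounds shown here alone, is whether the rise follows the hydroxyl or the chain carrying it. An ethyl or a hydroxymethyl group on this carbon would separate the two.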